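A Dimethylphenyl Exchange on a Weak Growth Inhibitor

The source may report more compounds than this note shows. Statements on the series, on what has been measured and on what is new or still open speak of the compounds shown alone.

For the measured compounds named here, compound 1 `COc1cc(Nc2ncc(C(F)(F)F)c(N3Cc4cccc(N(C)S(C)(=O)=O)c4C3)n2)c(OC)cc1Cl` gives 25600 nM in a functional assay on HepG2 cells (Homo sapiens) for antiproliferative activity, read by spectrophotometry, with a stated time of 2 days (a lower number here means a stronger inhibitor of growth, a higher number a weaker inhibitor of growth), and holds the higher of the two numbers measured so far. In this assay compound 2 `CN(c1cccc2c1CN(c1nc(Nc3ccc(Nc4ccccc4)cc3)ncc1C(F)(F)F)C2)S(C)(=O)=O` gives 8600 nM and so stands lower than compound 1 by more than the usual scatter.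

Compound 3 `Cc1ccc(Nc2ncc(C(F)(F)F)c(N3Cc4cccc(N(C)S(C)(=O)=O)c4C3)n2)c(C)c1` is still unmeasured and departs from compound 1 by 2,4-dimethylphenyl in place of 4-chloro-2,5-dimethoxyphenyl on a nitrogen on an aromatic ring with 2,4-dimethylphenyl in place of 4-chloro-2,5-dimethoxyphenyl on a nitrogen on an aromatic ring. Going by the values given here, no measured pair tests this exchange directly, so the evidence is thin. With compound 2 at 8600 nM as the only other reference, a small step toward a lower number is expected in this assay and it may not clear the scatter. The step expected is a 1.6-fold lower number from compound 1 to compound 3 (0.20 log units; within the scatter) and it would stay within the usual scatter. For compound 3 the expected value is 16000 nM with an estimated range from 6500 nM to 40000 nM as the likely span.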

Compound 3, concentration for 50% growth inhibition: 19100 nM
The estimate for compound 3 lay 1.2-fold (0.08 log units) below the measured number; measured number inside the range.
By their numbers in this assay, from the lowest: compound 2; then compounds 3 and 1 (each within the scatter of the next).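

Placing 2,4-dimethylphenyl in place of 4-chloro-2,5-dimethoxyphenyl on a nitrogen on an aromatic ring gives in this assay the step of a 1.3-fold lower number from compound 1 to compound 3 (0.13 log units; within the scatter) and is the first direct reading of an exchange at this position. The chlorine and the oxygen atoms of the leaving group are gone and the entering group holds carbon only, yet the two compounds cannot be told apart in this read-out, so at this position the assay does not separate these two substituted phenyl groups. No measurement shown bears on why these two groups read alike.

The exchange alters several substituents on the phenyl ring at once, so the compounds shown cannot say what the chlorine, the methoxy groups or the methyl groups each contribute, or whether their separate effects simply offset one another. Going by these compounds, it also remains open how this position would read with an amine, a carboxylic acid or a morpholine on the phenyl ring, all on the same shared core.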